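Nitro for Methyl on a Benzyloxy Acetophenone Series

This account rests on a few compounds, and the source may have more. Where it says the series, first, only, none or still open, it means among the compounds named here.

Measured compounds:
compound 1 `CC(=O)c1ccc(OCc2ccccc2C)cc1`, 77.1 nM
compound 2 `CC(=O)c1ccc(OCc2cccc(C)c2)cc1`, 86.3 nM
compound 3 `CC(=O)c1ccc(OCc2ccc(C)cc2)cc1`, 102 nM

In an assay on isolated protein for inhibition of Amine oxidase [flavin-containing] B (Homo sapiens), read by Amplex Red, with a stated time of 15 min (on this read-out higher numbers stand for weaker inhibition and lower numbers for stronger inhibition), compound 1 gives 77.1 nM, the lowest of the three numbers shown, though the others sit within the scatter of it: compound 2 gives 86.3 nM and compound 3 gives 102 nM, so no ranking among the three can be claimed. Compound 4 `CC(=O)c1ccc(OCc2ccccc2[N+](=O)[O-])cc1` differs from compound 1 by a single change: nitro in place of methyl on an aromatic carbon. For the measured compounds named here, no step between measured compounds resembles this change, so nothing among the three measured compounds sets its size. A modest move toward a higher number, near the edge of the scatter, is expected in this assay, amounting to a 1.9-fold higher number from compound 1 to compound 4 (0.29 log units; within the scatter). For compound 4 the estimate is 150 nM, with a range from 40 nM to 600 nM.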

Compound 4, half-maximal inhibitory concentration: 284 nM
Compound 4: the middle estimate sits 1.9-fold (0.28 log units) below what was measured; low and high end bracket the measured number.
By their numbers in this assay, from the lowest: compounds 1, 2 and 3 (each within the scatter of the next); then compound 4.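

In this assay, nitro in place of methyl on an aromatic carbon, ortho to a large group, gives a 3.7-fold higher number from compound 1 to compound 4 (0.57 log units; beyond the scatter). The three methyl compounds lay within the scatter of one another and showed no sensitivity to change, whereas this single replacement shows that the group at this place can alter the number. Nothing measured here accounts for the step.

From the compounds shown here alone, whether an amine or a methoxy group at this place would stay near compound 1 or move toward compound 4 remains open. So does whether nitro would have a similar effect where the methyl sits in compound 2 and compound 3.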